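This account rests on a few compounds, and the source may have more. Where it says the series, first, only, none or still open, it means among the compounds named here.

Compound 1 `COc1ccc(N/C=C\C(=O)c2nc(-c3ccc(C(F)(F)F)cc3)n3ccccc23)cc1OC` was tested in a functional assay on A549 cells (Homo sapiens) for cytotoxicity, read by MTT assay, with a stated time of 48 h; on this read-out lower numbers stand for stronger inhibition and higher numbers for weaker inhibition. In this assay compound 1 gives only a limit, > 30000 nM. Compound 2 `O=C(/C=C\Nc1ccc(Cl)cc1)c1nc(-c2ccc(C(F)(F)F)cc2)n2ccccc12` carries 4-chlorophenyl in place of 3,4-dimethoxyphenyl on an amine nitrogen. In this assay compound 2 gives 18500 nM, and the step is an at least 1.6-fold lower number from compound 1 to compound 2 (0.20 log units; that floor lies within the scatter). Compound 3 `COc1ccc(N/C=C\C(=O)c2nc(-c3ccc(F)cc3)n3ccccc23)cc1OC` differs from compound 1 in its core by fluoro in place of trifluoromethyl on an aromatic carbon. In this assay compound 3 gives only a limit, > 30000 nM. The step reads a step that the two limits leave unreadable from compound 1 to compound 3 because the limit of > 30000 nM in this assay, at which 2 of the 3 values shown sit, covers both of its ends.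

Compound 4 `O=C(/C=C\Nc1ccc(Cl)cc1)c1nc(-c2ccc(F)cc2)n2ccccc12` has not been measured. It stands to compound 3 as compound 2 stands to compound 1: the same change, (4-chlorophenyl in place of 3,4-dimethoxyphenyl on an amine nitrogen), made on the core of compound 3 instead. In this assay the step from compound 3 to compound 4 is expected to be an at least 1.3-fold lower number from compound 3 to compound 4 (0.13 log units; that floor lies within the scatter). That expectation rests on compound 2 and its value of 18500 nM, which the same change reached from compound 1. For compound 4 the estimate in this assay is 22000 nM, with a range from 10000 nM to 45000 nM.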

Compound 4, half-maximal inhibitory concentration: 5090 nM
Compound 4: the middle estimate sits 4.3-fold (0.64 log units) above what was measured; measured number below the stated range.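

In this assay, placing 4-chlorophenyl instead of 3,4-dimethoxyphenyl on the amine nitrogen of the core of compound 3 gives an at least 5.8-fold lower number from compound 3 to compound 4 (0.77 log units; beyond the scatter), and fluoro in place of trifluoromethyl, with 4-chlorophenyl kept, gives a 3.6-fold lower number from compound 2 to compound 4 (0.56 log units; beyond the scatter). Within the data shown here, the floor of the 4-chlorophenyl step lies beyond the scatter only on the core of compound 3, so this is the one pair that clearly shows the change carrying a real drop in the number. Both steps of this change start from a value that is only a limit, so neither size is fixed, and the data do not show that the change is larger on one core than on the other: the same change on two cores in this assay, an at least 1.6-fold lower number (0.20 log units; that floor lies within the scatter) from compound 1 to compound 2 and an at least 5.8-fold lower number (0.77 log units; beyond the scatter) from compound 3 to compound 4; the limit leaves it open whether they differ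

The fluoro step cannot be read with 3,4-dimethoxyphenyl in place, so it rests on a single pair. The compounds shown leave open how a nitrile or a methoxy group in place of the chlorine of the 4-chlorophenyl would read on either core.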